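This account rests on a few compounds, and the source may have more. Where it says the series, first, only, none or still open, it means among the compounds named here.

Measured in an assay on cells for inhibition of phosphatidylcholine:ceramide cholinephosphotransferase 2 (Homo sapiens), read by mass spectrometry, with stated times of 60 min and 30 min; on this read-out lower numbers stand for stronger inhibition and higher numbers for weaker inhibition:

Compound 1 `COc1cc(CN(C)C(=O)c2c(OCCCC3CCN(C(=O)OC(C)(C)C)CC3)c3ccccc3n(C)c2=O)cc(OC)c1`: 91 nM
Compound 2 `CCCOc1c(C(=O)N(C)Cc2cc(C(F)(F)F)cc(C(F)(F)F)c2)c(=O)n(C)c2ccccc12`: 2100 nM
Compound 3 `CCOc1cc(CN(C)C(=O)c2c(OCCCC3CCN(C(=O)OC(C)(C)C)CC3)c3ccccc3n(C)c2=O)cc(OCC)c1`: 380 nM

For the measured compounds named here, compound 2 stands with the highest number of the three, its nearest neighbour being compound 3 and the furthest compound 1, both of which differ from it in more than one place and so give no clean single step. Going by the values given here, the only single-place step measured is a 4.2-fold higher number from compound 1 to compound 3 (0.62 log units; beyond the scatter), which concerns the two alkoxy groups on the benzylic ring of the shared core, not the alkoxy chain on the core itself.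

Compound 4 `CC(C)CCOc1c(C(=O)N(C)Cc2cc(C(F)(F)F)cc(C(F)(F)F)c2)c(=O)n(C)c2ccccc12` differs from compound 2 by isopropyl in place of methyl on a saturated chain carbon, two bonds along the chain from an oxygen on an aromatic ring, that is, a propoxy group becomes an isopentyloxy group. Among the compounds with values here, no measured step touches this chain, so the step from compound 1 to compound 3 offers only a loose reference for how much a change of this size can move the number. The two compounds carrying a longer chain at that oxygen, compound 1 and compound 3, both show lower numbers than compound 2, but with other differences present at the same time.

The expectation is therefore a small step, a 1.6-fold lower number from compound 2 to compound 4 (0.21 log units; within the scatter), with wide uncertainty. Compound 4 is estimated at 1300 nM, in the range 400 nM to 4000 nM.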

Compound 4, half-maximal inhibitory concentration: 350 nM
The estimate for compound 4 lay 3.7-fold (0.57 log units) above the measured number; measured number below the stated range.
By their numbers in this assay, from the lowest: compound 1; then compounds 4 and 3 (each within the scatter of the next); then compound 2.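

In this assay, for the compounds shown here, replacing propoxy with isopentyloxy gives a 6.0-fold lower number from compound 2 to compound 4 (0.78 log units; beyond the scatter), the first measured evidence that the number responds to a change in the chain on this oxygen. Going by these compounds alone, the only earlier single-place step, a 4.2-fold higher number from compound 1 to compound 3 (0.62 log units; beyond the scatter), concerned a different part of the molecule, where 3,5-diethoxyphenyl in place of 3,5-dimethoxyphenyl went with weaker inhibition, whereas adding carbons to this chain goes with stronger inhibition. Nothing available explains why the number fell, so the reason for this step remains unknown.

A single step cannot separate the effect of the longer chain from that of the branch at its end, and a straight pentyloxy chain would help tell these two apart. From the compounds shown here alone, it also remains open how far this trend extends, for example to a still longer chain, and whether a chain ending in an amine or a carboxylic acid would go with a lower or a higher number in this assay.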